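Swapping One Methylnitrophenyl Isomer for Another

The source may hold more compounds than are shown below. What is called first, only, known or untested is meant among the compounds shown, and "the series" means these compounds.

Two nucleoside analogues have been measured in an assay on isolated protein for binding affinity to Equilibrative nucleoside transporter 1 (Homo sapiens); a higher number here means a weaker inhibitor, a lower number a stronger inhibitor. Compound 1 `OC[C@H]1O[C@@H](n2cnc3c(CSc4ccccc4F)ncnc32)[C@H](O)[C@@H]1O` gives 355 nM in this assay. Compound 2 `Cc1c(CNc2ncnc3c2ncn3[C@@H]2O[C@H](CO)[C@@H](O)[C@H]2O)cccc1[N+](=O)[O-]` gives 427 nM in this assay. Compound 2 holds the higher of the two numbers, but its nearest neighbour, compound 1, sits only slightly lower, and that gap lies within the scatter of repeated measurements; the two values therefore show no difference that can be read.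

Compound 3 `Cc1ccc(CNc2ncnc3c2ncn3[C@@H]2O[C@H](CO)[C@@H](O)[C@H]2O)cc1[N+](=O)[O-]` has not yet been measured. It differs from compound 2 by one change: 4-methyl-3-nitrophenyl in place of 2-methyl-3-nitrophenyl on a saturated chain carbon bound to a nitrogen on an aromatic ring. Within the data shown here, no step between two measured compounds covers this change, and nothing among the measured compounds tells how such an exchange is felt in this assay. The author therefore expects no step beyond the usual scatter from compound 2 to compound 3, with the direction left open. The author estimates for compound 3 a value of 420 nM in this assay, with a range from 150 nM to 1200 nM. The expected step is a 1.0-fold lower number from compound 2 to compound 3 (0.01 log units; within the scatter), meaning essentially no change.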

Compound 3, half-maximal inhibitory concentration: 1170 nM
Beside the measured number, compound 3's estimate is 2.8-fold (0.44 log units) below it; the measured number falls inside the stated range.
By their numbers in this assay, from the lowest: compounds 1 and 2 (each within the scatter of the next); then compound 3.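

On a saturated chain carbon bound to a nitrogen on an aromatic ring, 4-methyl-3-nitrophenyl in place of 2-methyl-3-nitrophenyl gives a 2.7-fold higher number from compound 2 to compound 3 (0.44 log units; beyond the scatter) in this assay and counts as a modest change. Among these compounds, the two groups hold the same atoms and the same counted features, so this pair shows that the number at this place can move with the arrangement of those atoms on the phenyl ring alone, something the earlier compounds could not show. No measurement is available that accounts for this difference.

This single pair of isomers leaves open whether a similar step would appear with another group on the ring, such as a methoxy group or an amine in place of the nitro group, or with the methyl group replaced by chlorine. It also leaves open whether the step would persist with a longer chain between the phenyl ring and the nitrogen, or whether a phenyl ring carrying only a methyl group would give a number closer to that of compound 2 or of compound 3.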